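Phenylsulfanyl replacing 4-chlorophenyl on a pyrimidine-type scaffold

A few compounds are considered here, and "the series" means these few. Any claim that something is new, unique, unknown or untested is made for them only; others in the source may bear on it.

The measured compounds:
compound 1, `CCOC(=O)c1cnc(C(C)(C)C)nc1NN1C(=O)C=C(C)C1=O`, 1000 nM
compound 2, `CCOC(=O)c1cnc(-c2ccc(Cl)cc2)nc1NN1C(=O)C=C(C)C1=O`, 300 nM
compound 3, `CCOC(=O)c1cnc(-c2cccc(Br)c2)nc1NN1C(=O)C=C(C)C1=O`, 700 nM

In a functional assay on Jurkat cells for inhibition of nuclear factor NF-kappa-B complex (Homo sapiens) (a higher number here means a weaker inhibitor, a lower number a stronger inhibitor), compound 2 gives the lowest of the three numbers; the nearest is a 2.3-fold higher number from compound 2 to compound 3 (0.37 log units; beyond the scatter), and the widest gap is a 3.3-fold lower number from compound 1 to compound 2 (0.52 log units; beyond the scatter). The change from compound 1 to compound 3, a 1.4-fold lower number from compound 1 to compound 3 (0.15 log units; within the scatter), lies within the scatter.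

Compound 4, `CCOC(=O)c1cnc(Sc2ccccc2)nc1NN1C(=O)C=C(C)C1=O`, has not yet been measured. It differs from compound 2 in one place: phenylsulfanyl in place of 4-chlorophenyl on an aromatic carbon. Going by the values given here, no measured step exchanges an aryl group for one joined through sulfur, so the nearest guides are the aryl variations among compounds 1, 2 and 3, all of which move the number by modest amounts. Since compound 2 already holds the lowest value, the expectation for compound 4 is a modest rise, a 1.7-fold higher number from compound 2 to compound 4 (0.22 log units; within the scatter), with the possibility of no change beyond the scatter. Compound 4 is estimated at 500 nM, within a range from 200 nM to 1300 nM.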

Compound 4, half-maximal inhibitory concentration: 1000 nM
The estimate for compound 4 lay 2.0-fold (0.30 log units) below the measured number; the measured number falls inside the stated range.
By their numbers in this assay, from the lowest: compound 2; then compounds 3, 1 and 4 (each within the scatter of the next).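

In this assay, putting phenylsulfanyl on the aromatic carbon between two ring nitrogen atoms gives up the advantage held by 4-chlorophenyl, with a 3.3-fold higher number from compound 2 to compound 4 (0.52 log units; beyond the scatter). The new group cannot be separated from the other two, with a 1.4-fold higher number from compound 3 to compound 4 (0.15 log units; within the scatter) and no change at the digits printed from compound 1 to compound 4 (within the scatter), so compound 2 is the only one of the four whose steps to all the others lie beyond the scatter, and a six-membered aromatic ring at this position does not by itself match it. Nothing available bears on why this step has the size it has.

This step introduces the sulfur link and removes the chlorine together, and the compounds shown cannot tell the two apart. Going by these compounds, a 4-chlorophenylsulfanyl group would separate them, while an amine or a phenoxy link at this position remains open.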